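Cytotoxicity notes: chloro for methyl on the core

The source may hold more compounds than are shown below. What is called first, only, known or untested is meant among the compounds shown, and "the series" means these compounds.

Compound 2 `Cc1ccn2nc(C)c(C(=O)NCc3ccc(N4CCC(c5ccc(OC(F)(F)F)cc5)CC4)cc3)c2c1` is the reference point of this note. In an ADME assay on Vero cells (Chlorocebus sabaeus) for cytotoxicity, read by CCK-8 assay, with a stated time of 72 h (on this read-out lower numbers stand for stronger inhibition and higher numbers for weaker inhibition), compound 2 gives only the limit of the assay, > 100000 nM. Its nearest measured neighbour is compound 1 `Cc1ccn2nc(C)c(C(=O)NCc3ccc(N4CCC(C(F)(F)F)CC4)cc3)c2c1`, which carries trifluoromethyl on a saturated ring carbon where compound 2 carries 4-(trifluoromethoxy)phenyl. In this assay compound 1 likewise returns the limit, > 100000 nM. The step that the two limits leave unreadable from compound 1 to compound 2 is therefore not readable in size, both ends sitting at the limit of > 100000 nM in this assay, at which 2 of the 3 values shown sit. Compound 3 `Cc1nn2ccc(C(C)(C)C)cc2c1C(=O)NCc1ccc(N2CCC(c3ccc(OC(F)(F)F)cc3)CC2)cc1` has no result in this assay, "not determined" (no result reported).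

Compound 4 `Cc1nn2ccc(Cl)cc2c1C(=O)NCc1ccc(N2CCC(c3ccc(OC(F)(F)F)cc3)CC2)cc1` differs from compound 2 in one place: chloro in place of methyl on an aromatic carbon. For the measured compounds named here, none of the measured steps touches this position, and the single measured step in the set is unreadable, so there is no quantitative guide for the exchange. What can be said is that both measured compounds sit at the limit and that the change is a single-atom swap with no change in donors, acceptors or charge.

On that basis compound 4 is expected to remain at the limit as well, so the expected step that the limit leaves unreadable from compound 2 to compound 4 is none beyond the scatter. The estimate for compound 4 in this assay is 150000 nM, with a range from 40000 nM to 600000 nM, most likely reported once more only as a limit.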

Compound 4, half-maximal inhibitory concentration: > 100000 nM
Compound 4 ended at the assay's limit; the forecaster's own chance of this, stated with the estimate: 85%; the middle value lies beyond the limit too.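

No new step can be read between compound 2 and compound 4, because each gives only a limit of this assay and not a number: the limit of > 100000 nM in this assay, at which 3 of the 4 values shown sit.

The compounds shown leave open at what concentration, if any, compound 2 and compound 4 would reach half-maximal inhibition in this assay, and whether chloro and methyl differ there at all.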